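The source may hold more compounds than are shown below. What is called first, only, known or untested is meant among the compounds shown, and "the series" means these compounds.

Measured compounds:
compound 1 `N#CC1=C(N)Oc2c(c3nc4ccccc4nc3c3ccccc23)C12C(=O)N(Cc1cnnn1-c1ccc(Cl)cc1)c1ccccc12`
compound 2 `CCOc1ccccc1-n1nncc1CN1C(=O)C2(C(C#N)=C(N)Oc3c2c2nc4ccccc4nc2c2ccccc32)c2ccccc21`
compound 3 `N#CC1=C(N)Oc2c(c3nc4ccccc4nc3c3ccccc23)C12C(=O)N(Cc1cnnn1-c1ccc([N+](=O)[O-])cc1)c1ccccc12`

In an ADME assay on L02 cells (Homo sapiens) for antiproliferative activity, read by MTT assay, with a stated time of 48 h (on this read-out lower numbers stand for stronger inhibition and higher numbers for weaker inhibition), compound 1 gives > 50000 nM, which is a limit of the assay and not a number. In this assay compound 2 gives > 50000 nM, likewise a limit. In this assay compound 3 gives > 50000 nM, also a limit. All three values sit at the limit of > 50000 nM in this assay, at which 3 of the 3 values shown sit, so compound 1 stands at the limit with the others and no order among them can be read.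

Compound 4 `N#CC1=C(N)Oc2c(c3nc4ccccc4nc3c3ccccc23)C12C(=O)N(Cc1cnnn1-c1cccc(S(N)(=O)=O)c1)c1ccccc12` differs from compound 1 by 3-sulfamoylphenyl in place of 4-chlorophenyl on an aromatic nitrogen. The steps a step that the two limits leave unreadable from compound 1 to compound 2 and a step that the two limits leave unreadable from compound 1 to compound 3 concern the same position on the aromatic nitrogen, yet both are unreadable between two limits, as is a step that the two limits leave unreadable from compound 2 to compound 3. The data therefore offer no readable step to carry over, and the expectation is a step that the limit leaves unreadable from compound 1 to compound 4 of no readable size in this assay. Compound 4 is accordingly estimated at 60000 nM, between 20000 nM and 200000 nM, most likely again a limit.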

Compound 4, half-maximal inhibitory concentration: > 50000 nM
Compound 4: a limit, no number; the forecaster's own chance of this, stated with the estimate: 85%; the middle value does not contradict the limit.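

Compound 4 gives no readable new step against compound 1, compound 2 or compound 3 in this assay, as all four values are limits and not numbers: the limit of > 50000 nM in this assay, at which 4 of the 4 values shown sit.

The compounds shown leave open whether any of these groups on the aromatic nitrogen changes the read-out in this assay at all.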